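A few compounds are considered here, and "the series" means these few. Any claim that something is new, unique, unknown or untested is made for them only; others in the source may bear on it.

The study covers compound 1, `Cc1ccc(Nc2cc(C)nc(SCc3nc4ccccc4[nH]3)n2)cc1`, and compound 2, `Cc1cc(Nc2ccc(F)cc2)nc(SCc2nc3ccccc3[nH]2)n1`, which share a core and differ only by a fluoro in place of a methyl on an aromatic carbon. In a functional assay on MGC-803 cells (Homo sapiens) for cytotoxicity, read by MTT assay, with a stated time of 72 h (a higher number here means a weaker inhibitor, a lower number a stronger inhibitor), compound 1 gives 7390 nM and compound 2 gives 5770 nM. Going by the values given here, the single step between them, a 1.3-fold lower number from compound 1 to compound 2 (0.11 log units; within the scatter), stays within the scatter, so compound 2 holds the lowest of the two numbers without being separable from compound 1.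

Compound 3, `Cc1cc(NNC(N)=S)nc(SCc2nc3ccccc3[nH]2)n1`, departs from compound 2 by a change of a different kind: a group of 4 heavy atoms (1 carbon, 2 nitrogen, 1 sulfur; no ring) in place of a group of 7 heavy atoms (6 carbon, 1 fluorine; one six-membered aromatic ring of carbon only), on a nitrogen on an aromatic ring. The 4-fluorophenyl that leaves carries the fluoro whose exchange was tested in the step already shown, but no measured step removes that ring altogether, so the data offer no guide to the size or direction of this move in this assay. Compound 3 is therefore expected to land near the mark of compound 2, 5770 nM, with broad uncertainty. The estimate for compound 3 is 8000 nM, ranging from 2000 nM to 32000 nM. That corresponds to an expected step of a 1.4-fold higher number from compound 2 to compound 3 (0.14 log units; within the scatter).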

Compound 3, half-maximal inhibitory concentration: > 100000 nM
Compound 3: a limit, no number (the forecaster's own chance of this, stated with the estimate: 20%); at least 12-fold (1.09 log units) between middle value and limit.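

In this assay compound 3 gives > 100000 nM, which is a limit of the assay and not a number. Unlike the exchange of substituents on the aromatic ring, which gave a 1.3-fold lower number from compound 1 to compound 2 (0.11 log units; within the scatter), replacing the ring itself on this nitrogen has a large effect: the 4-fluorophenyl gives way to the group of 4 heavy atoms with an at least 17-fold higher number from compound 2 to compound 3 (1.23 log units; beyond the scatter), and the same group replaces the ring of the methyl-bearing compound with an at least 13-fold higher number from compound 1 to compound 3 (1.13 log units; beyond the scatter), so the position is not indifferent to what it carries. Both steps are bounded on one side only, and compound 3 is the compound that sits at the limit: the limit of > 100000 nM in this assay, at which 1 of the 3 values shown sits.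

The compounds shown do not separate the loss of the six-membered aromatic ring from the arrival of the new group, since both happen in the same change. Going by these compounds, a cyclohexyl ring, a short alkyl chain or a plain amine on this nitrogen would show which of the two carries the step, and the true value of compound 3 remains unknown.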